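Carboxy in place of the four-atom group

The source may report more compounds than this note shows. Statements on the series, on what has been measured and on what is new or still open speak of the compounds shown alone.

Among the measured compounds shown here, in a toxicity assay on CCRF-CEM cells (Homo sapiens) for cytotoxicity (a lower number here means that less compound is tolerated, a higher number that more compound is tolerated), compound 1 `COc1cccc2c1nc(-c1c(F)cccc1F)n2Cc1c(F)cccc1F` gives 44.3 uM and compound 2 `N=C(NO)c1cccc2c1nc(-c1c(F)cccc1F)n2Cc1c(F)cccc1F` gives 23.1 uM, so compound 2 stands within the scatter of the only other number. Compound 3 `O=C(O)c1cccc2c1nc(-c1c(F)cccc1F)n2Cc1c(F)cccc1F` carries a carboxy group on the same aromatic carbon, with the change being (a group of 3 heavy atoms (1 carbon, 2 oxygen; no ring) in place of a group of 4 heavy atoms (1 carbon, 2 nitrogen, 1 oxygen; no ring), on an aromatic carbon). For the measured compounds named here, the one measured step that bears on this, a 1.9-fold lower number from compound 1 to compound 2 (0.28 log units; within the scatter), also exchanges the group on that carbon. No step beyond the scatter is therefore expected in this assay, and no firm direction. The expected step is a 1.3-fold higher number from compound 2 to compound 3 (0.11 log units; within the scatter). Compound 3 is estimated at 30 uM, with a range of 12 uM to 80 uM.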

Compound 3, half-maximal toxic concentration: 23.5 uM
Compound 3: the middle estimate sits 1.3-fold (0.11 log units) above what was measured; measured number inside the range.
By their numbers in this assay, from the lowest: compounds 2, 3 and 1 (each within the scatter of the next).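

In this assay the steps of a 1.0-fold higher number from compound 2 to compound 3 (0.01 log units; within the scatter) and a 1.9-fold lower number from compound 1 to compound 3 (0.28 log units; within the scatter) show that carboxy on this aromatic carbon cannot be told apart from either the four-atom group or methoxy. Among the compounds shown here, all three groups at this position now stand within the scatter of one another, so the single earlier step was not an isolated case. No available measurement explains why these numbers stay together.

From the compounds shown here alone, whether an amine or a longer alkyl chain on this carbon would give a step beyond the scatter remains open. Going by these compounds, the effect of changes elsewhere on the shared core also remains open.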